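Methoxy on the cyclobutyl amide of the alkynylthiazole series

The compounds below may be only part of what the source reports. "The series", "measured", "known", "first", "only" and "open" are said of these compounds alone.

Measured compounds:
compound 1 `CC(C)CN1CCc2nc(C#Cc3ccccc3)sc2C1`: > 10000 nM (a limit)
compound 2 `O=C(C1CC12CCC2)N1CCc2nc(C#Cc3ccccc3)sc2C1`: 3.9 nM
compound 3 `O=C(C1CCC1)N1CCc2nc(C#Cc3ccccc3)sc2C1`: > 10000 nM (a limit)

In an assay on HEK293 cells for positive allosteric modulation of metabotropic glutamate receptor 5 (Homo sapiens), read by FLIPR, with a stated time of 1 h (on this read-out lower numbers stand for an effect already at smaller amounts and higher numbers for an effect only at larger amounts of compound), compound 3 gives only a limit, > 10000 nM. Compound 3 thus sits with compound 1 at the limit of > 10000 nM in this assay, at which 2 of the 3 values shown sit, whereas compound 2 gives a number. Compound 4 `COC1CC(C(=O)N2CCc3nc(C#Cc4ccccc4)sc3C2)C1` differs from compound 3 by methoxy in place of hydrogen on a saturated ring carbon. Within the data shown here, no measured step changes this position; the steps that touch the amide side are an at least 2500-fold lower number from compound 1 to compound 2 (3.40 log units; beyond the scatter) and an at least 2500-fold higher number from compound 2 to compound 3 (3.40 log units; beyond the scatter), both large, which show this region moves the read-out strongly but say nothing about a methoxy. The expected step of an at least 2.5-fold lower number from compound 3 to compound 4 (0.39 log units; beyond the scatter) is therefore uncertain. Compound 4 is estimated at 4000 nM, ranging from 300 nM to 30000 nM, with a real chance that only a limit is reported again.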

Compound 4, half-maximal effective concentration: 640 nM
For compound 4 the middle estimate is 6.3-fold (0.80 log units) above the measured one; the measured number falls inside the stated range.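

The 3-methoxycyclobutyl amide gives a readable number where the plain cyclobutyl amide does not, with an at least 15-fold lower number from compound 3 to compound 4 (1.19 log units; beyond the scatter); against the isobutyl amine the result is an at least 15-fold lower number from compound 1 to compound 4 (1.19 log units; beyond the scatter). The gain still falls short of the amide carrying a three-membered and a four-membered ring, with a 160-fold higher number from compound 2 to compound 4 (2.22 log units; beyond the scatter). Compound 1 and compound 3 remain the only ones at a limit: the limit of > 10000 nM in this assay, at which 2 of the 4 values shown sit.

Open, on these data alone, is whether a hydroxy, an ethoxy or an amine on the same ring carbon would give a similar number. Also open, as far as these compounds go, is what methoxy would do on the ring system of compound 2.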